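The compounds below may be only part of what the source reports. "The series", "measured", "known", "first", "only" and "open" are said of these compounds alone.

In a functional assay on B16-F1 cells (Mus musculus) for antiproliferative activity, read by sulforhodamine B assay, with a stated time of 48 h (on this read-out lower numbers stand for stronger inhibition and higher numbers for weaker inhibition), compound 1 `CCCCCCCCCCNC(=O)c1c[nH]c(-c2ccccc2)n1` reads > 30000 nM as a limit of the assay, not a number. For the measured compounds named here, compound 2 `CCCCCCCCCCCCCCNC(=O)[C@@H]1CNC(c2ccccc2)=N1` gives 7200 nM as the only actual number so far, which makes it the sole numerical reference point for what follows.

Compound 3 `CCCCCCCCCCCCCCCCNC(=O)[C@@H]1CNC(c2ccccc2)=N1` carries one change relative to compound 2, namely ethyl in place of hydrogen on a saturated chain carbon, ten or more bonds along the chain from an amide-type nitrogen with ethyl in place of hydrogen on a saturated chain carbon, ten or more bonds along the chain from an amide-type nitrogen. Going by the values given here, no measured step between two compounds is available to scale this change, so the expectation rests on compound 2 at 7200 nM and on the small size of the change.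

In this assay a small shift toward stronger inhibition is the expected direction, with no change beyond the scatter remaining quite possible. The expected move a 1.8-fold lower number from compound 2 to compound 3 (0.26 log units; within the scatter) is about the size of the usual scatter. Compound 3 is estimated at 4000 nM in this assay with an expected range from 1500 nM to 12000 nM for now.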

Compound 3, half-maximal inhibitory concentration: 5700 nM
Compound 3: the middle estimate sits 1.4-fold (0.15 log units) below what was measured; measured number inside the range.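

For the compounds shown here, this is the first step that can be read, and in this assay the change of ethyl in place of hydrogen on a saturated chain carbon, ten or more bonds along the chain from an amide-type nitrogen, gives a 1.3-fold lower number from compound 2 to compound 3 (0.10 log units; within the scatter). The position therefore accepts a chain extension of 2 carbon atoms, with no hydrogen-bond donor or acceptor added, and the read-out stays within the scatter. At this depth along the chain, the added carbons leave compound 3 indistinguishable from compound 2, so the low-micromolar-range reading of the pair is not tied to this exact chain end, and nothing at hand gives a cause for that.

Going by these compounds, whether a longer chain, or an amine or a carboxylic acid on that same saturated chain carbon, would also leave the number within the scatter stays open. Compound 1 gives > 30000 nM, which is a limit of the assay and not a number, and it differs from compound 2 and compound 3 in more than one place, so steps to it cannot be read.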